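Thiazole in Place of Furan on the Chlorophenyl Arm

The compounds below may be only part of what the source reports. "The series", "measured", "known", "first", "only" and "open" are said of these compounds alone.

Compound 1, `Cn1nc2c(=O)n(CC3(O)CCN(Cc4ccc(-c5ccoc5)cc4Cl)CC3)cnc2c1-c1ccc(CN)cc1`, gives 177 nM in an assay on isolated protein for inhibition of ubiquitin carboxyl-terminal hydrolase 7 (Homo sapiens), with stated times of 30 min and 2 h; on this read-out higher numbers stand for weaker inhibition and lower numbers for stronger inhibition.
Compound 2, `Cn1nc2c(=O)n(CC3(O)CCN(Cc4ccc(-c5ccco5)cc4Cl)CC3)cnc2c1-c1ccc(F)cc1`, gives 64.5 nM in this assay.

Of the two numbers shown, compound 1 holds the higher one, and compound 2 the lower; the gap between them lies beyond the usual scatter of the measurement. Within the data shown here, compound 1 and compound 2 differ from one another in more than one place, so no single step can be drawn between them, and the two values are reported only as they stand.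

Compound 3, `Cn1nc2c(=O)n(CC3(O)CCN(Cc4ccc(-c5cncs5)cc4Cl)CC3)cnc2c1-c1ccc(CN)cc1`, differs from compound 1 in one place: 1,3-thiazol-5-yl in place of furan-3-yl on an aromatic carbon. Among the measured compounds shown here, no measured pair in this set isolates a change of this kind, so nothing in the data says which way such a step should run. The change is small in size and keeps a five-membered aromatic ring at the same place, so the expected step in this assay is a 1.1-fold lower number from compound 1 to compound 3 (0.04 log units; within the scatter), a change not beyond the scatter. Compound 3 is accordingly estimated at 160 nM, with a range from 60 nM to 420 nM.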

Compound 3, half-maximal inhibitory concentration: 117 nM
The estimate for compound 3 lay 1.4-fold (0.14 log units) above the measured number; the measured number falls inside the stated range.
By their numbers in this assay, from the lowest: compounds 2, 3 and 1 (each within the scatter of the next, the first and the last beyond it).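

In this assay, among these compounds, the first measured step at this place, on an aromatic carbon meta to a chloro group and para to a large group, is a 1.5-fold lower number from compound 1 to compound 3 (0.18 log units; within the scatter). The five-membered aromatic ring here can thus carry 2 hetero atoms, nitrogen and sulfur, in place of a single oxygen without a shift that stands clear of the scatter, so this one exchange leaves the number effectively unchanged. Nothing measured for these compounds offers a reason for this outcome.

Going by these compounds, it remains open whether a pyridine ring, a morpholine or a carboxylic acid at the same place would hold the number equally well. Also open, on these data alone, is whether 1,3-thiazol-5-yl would behave the same way with the other parts of compound 2 around it.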